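Hydrazide to hydrazone on a shared core: cytotoxicity estimate

This account rests on a few compounds, and the source may have more. Where it says the series, first, only, none or still open, it means among the compounds named here.

Measured compounds:
compound 1, `Cc1ccc(C(=O)NNC(=O)Cn2c(=O)c(Cc3ccccc3)nc3ccccc32)cc1`, 49.7 nM
compound 2, `O=C(Cn1c(=O)c(Cc2ccccc2)nc2ccccc21)NN=c1c(=O)c2ccccc2c1=O`, 7.98 nM

Compound 1 stands highest of the two numbers in an ADME assay on cells (Epithelial cell, Rattus norvegicus) for cytotoxicity, read by MTT assay; on this read-out lower numbers stand for stronger inhibition and higher numbers for weaker inhibition; its nearest neighbour is compound 2, whose number is lower by a margin beyond the usual scatter, so compound 2 shows the stronger inhibition of the pair.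

Compound 3, `O=C(Cn1c(=O)c(Cc2ccccc2)nc2ccccc21)N/N=C/c1ccccc1O`, has not been measured in this assay. It differs from compound 1 at a single place: a group of 9 heavy atoms (7 carbon, 1 nitrogen, 1 oxygen; one six-membered aromatic ring of carbon only) in place of a group of 10 heavy atoms (8 carbon, 1 nitrogen, 1 oxygen; one six-membered aromatic ring of carbon only), on an amide-type nitrogen. Within the data shown here, no step between measured compounds describes this kind of change, so the expectation rests only on the two values shown. Because compound 2 gives 7.98 nM with a different group on the same amide-type nitrogen, a number somewhat lower than that of compound 1 is expected for compound 3, with the step of a 2.0-fold lower number from compound 1 to compound 3 (0.30 log units; within the scatter) estimated as modest in the direction of stronger inhibition. For compound 3 the estimated value is 25 nM, within a range from 8 nM to 80 nM.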

Compound 3, half-maximal inhibitory concentration: 8.12 nM
Estimate against measurement, compound 3: 3.1-fold (0.49 log units) above, within the range that was stated.
By their numbers in this assay, from the lowest: compounds 2 and 3 (each within the scatter of the next); then compound 1.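

In this assay, the change on the amide-type nitrogen, with ((4-methylphenyl)carbonyl)amino leaving, gives a 6.1-fold lower number from compound 1 to compound 3 (0.79 log units; beyond the scatter) and so lies beyond the usual scatter. Compound 3 gives 8.12 nM and compound 2 gives 7.98 nM, values within the scatter of each other, so two different groups at this place now share a number well under that of compound 1. No measurement shown here accounts for this step.

The compounds shown leave open whether a group carrying an amine or a carboxylic acid in place of these aromatic groups would keep a number of this size. They also leave open whether a plain longer carbon chain on this nitrogen would give the number of compound 1 or that of compound 3.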